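A few compounds are considered here, and "the series" means these few. Any claim that something is new, unique, unknown or untested is made for them only; others in the source may bear on it.

Measured so far:
Compound 1 `O=C1C(Nc2ccccc2)=CC(=O)c2c1nc1n2[C@H]2OC[C@@H](O)[C@H]2OC1`: 3560 nM
Compound 2 `CCc1ccc(NC2=CC(=O)c3c(nc4n3[C@H]3OC[C@@H](O)[C@H]3OC4)C2=O)cc1`: > 4000 nM
Compound 3 `Cc1ccc(NC2=CC(=O)c3c(nc4n3[C@H]3OC[C@@H](O)[C@H]3OC4)C2=O)cc1C`: 4090 nM

These values come from a functional assay on ECa-109 cells for inhibition, with ECa-109 cell line (Homo sapiens) as the target, read by sulforhodamine B assay; a lower number here means a stronger inhibitor, a higher number a weaker inhibitor. For compound 2, > 4000 nM is a limit of the assay and not a number. Compound 3, at 4090 nM, stands level with compound 1 within the scatter, as a 1.1-fold higher number from compound 1 to compound 3 (0.06 log units; within the scatter) shows.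

Compound 4 `O=C1C(N2CCCCC2)=CC(=O)c2c1nc1n2[C@H]2OC[C@@H](O)[C@H]2OC1` carries piperidin-1-yl in place of (3,4-dimethylphenyl)amino on a double-bonded ring carbon.

Going by the values given here, two measured steps bear on this change, and only loosely: a 1.1-fold higher number from compound 1 to compound 3 (0.06 log units; within the scatter), and an at least 1.1-fold higher number from compound 1 to compound 2 (0.05 log units; that floor lies within the scatter). Both keep an aromatic ring on the amine nitrogen, so neither measures the exchange made in compound 4. Neither step gives a direction, so no shift beyond the scatter is expected, though the uncertainty is wide. The expected change is a 1.2-fold lower number from compound 3 to compound 4 (0.07 log units; within the scatter). For compound 4, the estimated value in this assay is 3500 nM, with an expected range of 1200 nM to 9000 nM.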

Compound 4, half-maximal inhibitory concentration: > 8000 nM
Compound 4: a limit, no number (the forecaster's own chance of this, stated with the estimate: 25%); at least 2.2-fold (0.35 log units) between middle value and limit.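

Compound 4 gives > 8000 nM in this assay, which is a limit of the assay and not a number: the limit of > 8000 nM in this assay, at which 1 of the 4 values shown sits.

Among the compounds shown, this is the first change at this double-bonded ring carbon to reach beyond the scatter, with piperidin-1-yl in place of anilino giving an at least 2.2-fold higher number from compound 1 to compound 4 (0.35 log units; beyond the scatter). Against the dimethylated aryl compound the result is less firm, at an at least 1.9-fold higher number from compound 3 to compound 4 (0.29 log units; that floor lies within the scatter), and the step from compound 2 to compound 4 cannot be read.

Piperidin-1-yl differs from the arylamino groups in two ways at once, losing both the aromatic ring and the hydrogen-bond donor, so the compounds shown leave open which of these matters. Cyclohexylamino or N-methylanilino, each changing only one of the two, would separate them.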